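This account rests on a few compounds, and the source may have more. Where it says the series, first, only, none or still open, it means among the compounds named here.

Measured compounds:
Compound 1, `C/C(=N\NC(=O)c1cccc(S(=O)(=O)N2CCOCC2)c1)c1cccc(N)c1`, in a functional assay on EC9706 cells (Homo sapiens) for antiproliferative activity, read by MTT assay, with a stated time of 72 h (a higher number here means a weaker inhibitor, a lower number a stronger inhibitor), gives > 100000 nM, which is a limit of the assay and not a number.
Compound 2, `C/C(=N\NC(=O)c1cccc(S(=O)(=O)N2CCOCC2)c1)c1ccccc1O`, in this assay gives 1220 nM.
Compound 3, `C/C(=N\NC(=O)c1cccc(S(=O)(=O)N2CCOCC2)c1)c1ccc(O)cc1`, in this assay gives 71400 nM.

Compound 2 stands lowest among the two numbers actually reported in this assay; its nearest neighbour is compound 3, and a 59-fold higher number from compound 2 to compound 3 (1.77 log units; beyond the scatter). The step from compound 1 to compound 2 is also large: an at least 81-fold lower number from compound 1 to compound 2 (1.91 log units; beyond the scatter). Both steps show that the 2-hydroxyphenyl of compound 2 carries the activity seen here, while a 4-hydroxyphenyl alone does not.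

Compound 4, `C/C(=N\NC(=O)c1cccc(S(=O)(=O)N2CCOCC2)c1)c1cc(O)ccc1O`, has not been measured. It differs from compound 2 by hydroxy in place of hydrogen on an aromatic carbon. The 2-hydroxyphenyl is kept, and a second hydroxy enters at the position para to the hydroxy group. Among the compounds with values here, no measured step adds a second hydroxy to an already active ring, so the bearing of compound 3 on it is indirect. Compound 4 is therefore expected to stay close to compound 2, with a 2.0-fold higher number from compound 2 to compound 4 (0.31 log units; beyond the scatter) as the estimated step, and the expected value for compound 4 in this assay is 2500 nM, within 600 nM to 12000 nM.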

Compound 4, half-maximal inhibitory concentration: 3510 nM
For compound 4 the middle estimate is 1.4-fold (0.15 log units) below the measured one, within the range that was stated.
By their numbers in this assay, from the lowest: compound 2; then compound 4; then compound 3. At a limit, above all of these: compound 1.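

Adding a hydroxy para to the hydroxy group of the 2-hydroxyphenyl gives a 2.9-fold higher number from compound 2 to compound 4 (0.46 log units; beyond the scatter) in this assay and so shows that this position accepts a second hydroxy at a modest cost, something no earlier compound could show. Against the lone 4-hydroxyphenyl, the 2,5-dihydroxyphenyl gives a 20-fold lower number from compound 3 to compound 4 (1.31 log units; beyond the scatter) and so keeps most of the lead seen with the 2-hydroxyphenyl. Against the 3-aminophenyl, the change gives an at least 28-fold lower number from compound 1 to compound 4 (1.45 log units; beyond the scatter) but this is only a floor, as the starting value is a limit of the assay and not a number: the limit of > 100000 nM in this assay, at which 1 of the 4 values shown sits.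

Going by these compounds, whether a methoxy, an amine or a fluorine at this position would be accepted as the hydroxy is remains open. So does whether a second hydroxy elsewhere on the ring would behave in the same way.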